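Benzoyl in Place of Oxan-4-yl on a Ring Nitrogen

A few compounds are considered here, and "the series" means these few. Any claim that something is new, unique, unknown or untested is made for them only; others in the source may bear on it.

Compound 2 `CC(C)(C)c1cc(NC(=O)[C@@H]2CCCCN2C2CCOCC2)no1` is the reference point here. Among the measured compounds shown here, in an ADME assay (liver) for metabolic stability, with Liver microsome (Homo sapiens) as the target, read by LC-MS, using microsomes and NADPH, tested at 1 uM (a higher number here means that the compound lasts longer, a lower number that the compound disappears faster), compound 2 gives 0.317 h, which is the higher of the two numbers measured so far. For the measured compounds named here, its only neighbour is compound 1 `CC(C)(C)c1cc(NC(=O)[C@@H]2CCCCN2C2CC2)no1`, which in this assay gives 0.183 h; the difference, a 1.7-fold higher number from compound 1 to compound 2 (0.24 log units; within the scatter), comes from exchanging cyclopropyl for oxan-4-yl on the amine nitrogen in the ring and is too small to count as a real change.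

Compound 3 `CC(C)(C)c1cc(NC(=O)[C@@H]2CCCCN2C(=O)c2ccccc2)no1` carries a different group at the same spot: benzoyl in place of oxan-4-yl on an amine nitrogen in a ring. Going by the values given here, the one measured step that bears on this, the step from compound 1 to compound 2, also swapped the group on that nitrogen and stayed within the scatter. Among the compounds with values here, no measured step, however, placed a benzoyl or any other group containing a carbonyl on that nitrogen, so the comparison is only loose.

On this thin basis the expected step of a 1.3-fold higher number from compound 2 to compound 3 (0.10 log units; within the scatter) is small, with the number for compound 3 estimated at 0.4 h, somewhere between 0.15 h and 1 h.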

Compound 3, half-life: 0.683 h
For compound 3 the middle estimate is 1.7-fold (0.23 log units) below the measured one, and the stated range covers the measured number.
By their numbers in this assay, from the lowest: compounds 1 and 2 (each within the scatter of the next); then compound 3.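

The position on the ring nitrogen turns out to be able to move the number in this assay, which the swap between the two earlier groups could not show. Benzoyl gives the first steps here that lie beyond the scatter, though both are modest (a 2.2-fold higher number from compound 2 to compound 3 (0.33 log units; beyond the scatter)) and (a 3.7-fold higher number from compound 1 to compound 3 (0.57 log units; beyond the scatter)). Cyclopropyl and oxan-4-yl both attach to the nitrogen through a saturated ring carbon, while benzoyl attaches through a carbonyl and brings an aromatic ring of carbon only, so this is also the first change of the type of group on that nitrogen rather than just its ring. Nothing available here explains the rise.

Benzoyl brings the carbonyl and the aromatic ring together, so the compounds shown leave open which of the two goes with the higher number. An acetyl group would have the carbonyl without the aromatic ring and a benzyl group would have the aromatic ring without the carbonyl, and how either would compare with compound 3 is not known from these compounds.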